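The source may hold more compounds than are shown below. What is called first, only, known or untested is meant among the compounds shown, and "the series" means these compounds.

Measured so far:
- compound 1 `O=C(CCCCC(S)CCS)NO`: "not active" (no number reported)
- compound 2 `O=C(CCCCC(S)CCS)Nc1ccccc1`: 6.38%
- compound 3 `O=C(CCCCC(S)CCS)Nc1cccc(C(F)(F)F)c1`: 13.7%

Going by the values given here, in a functional assay on HO8910 cells (Homo sapiens) for inhibition, read by MTT assay, with a stated time of 24 h, tested at 1 ug/mL (on this read-out lower numbers stand for less inhibition of growth and higher numbers for more inhibition of growth at the one concentration tested), compound 2 gives 6.38%, one of only two numbers, and compound 1 gives none. Compound 4 `COc1ccc(NC(=O)CCCCC(S)CCS)cc1` is compound 2 with methoxy in place of hydrogen on an aromatic carbon, para to a large group. Among the compounds with values here, one measured step bears on this change, trifluoromethyl in place of hydrogen on an aromatic carbon, which gives a number 7.3 percentage points higher from compound 2 to compound 3 (within the scatter). Within the data shown here, no measurement with methoxy exists, so a single small step is the only guide. The expected change is none beyond the scatter, an estimated a number 3.6 percentage points higher from compound 2 to compound 4 (within the scatter). For compound 4 the estimate in this assay is 10%, with an expected range of 2% to 24%.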

Compound 4, percent growth inhibition at one concentration: 1.79%
For compound 4 the middle estimate is 8.2 percentage points above the measured one; measured number below the stated range.
By their numbers in this assay, from the lowest: compounds 4, 2 and 3 (each within the scatter of the next, the first and the last beyond it).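

In this assay methoxy on an aromatic carbon, para to a large group, gives a number 4.6 percentage points lower from compound 2 to compound 4 (within the scatter) and thus no change beyond the scatter at this place on the ring. Going by these compounds alone, the earlier compounds carried no group at this place, so this is its only reading. No measured evidence bears on the result. Still open, as far as these compounds go, is how an amine or a carboxylic acid would read at this place, and whether trifluoromethyl here would also stay within the scatter of compound 2.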